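The source may hold more compounds than are shown below. What is called first, only, known or untested is meant among the compounds shown, and "the series" means these compounds.

Working notes on the quinoline ether amide series.

Compound 1 `COc1ccc2nc(C)cc(OCC(=O)Nc3ccccc3)c2c1` is the plain phenyl amide of the shared core; in a physicochemical assay for solubility, in phosphate buffer, measured as kinetic solubility, with a stated time of 1 h, at pH 7.4 (a lower number here means a less soluble compound, a higher number a more soluble compound), compound 1 gives 63000 nM. Compound 2 `COc1ccc2nc(C)cc(OCC(=O)Nc3ccc(Br)c(C)c3)c2c1` carries a 4-bromo-3-methylphenyl group on the amide nitrogen; in this assay compound 2 gives only a limit, < 1000 nM, and the limit of < 1000 nM in this assay, at which 1 of the 3 values shown sits, marks it as such. Compound 3 `COc1ccc2nc(C)cc(OCC(=O)Nc3ccc(Cl)cc3Cl)c2c1` carries a 2,4-dichlorophenyl group on the same nitrogen; in this assay compound 3 gives 20500 nM. Among the two numbers available, compound 3 stands lowest, with compound 1 nearest to it: a 3.1-fold lower number from compound 1 to compound 3 (0.49 log units; beyond the scatter). The other steps are an at least 63-fold lower number from compound 1 to compound 2 (1.79 log units; beyond the scatter) and an at least 20-fold higher number from compound 2 to compound 3 (1.31 log units; beyond the scatter).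

Compound 4 `COc1ccc2nc(C)cc(OCC(=O)Nc3ccccn3)c2c1` is the next member: pyridin-2-yl in place of 2,4-dichlorophenyl on an amide-type nitrogen. Among the compounds with values here, two measured steps bear on it, both involving an aryl amide substituent. The step from compound 1 to compound 3 was modest and downward on adding two chlorines; the step from compound 2 to compound 3 was large. Removing both chlorines and bringing in a ring nitrogen should at least undo the drop seen from compound 1 to compound 3, so an upward step is expected, of a size near a 3.9-fold higher number from compound 3 to compound 4 (0.59 log units; beyond the scatter). Compound 4 is therefore estimated at 80000 nM in this assay, within a range of 25000 nM to 250000 nM.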

Compound 4, solubility: 29000 nM
Beside the measured number, compound 4's estimate is 2.8-fold (0.44 log units) above it, within the range that was stated.
By their numbers in this assay, from the lowest: compounds 3 and 4 (each within the scatter of the next); then compound 1. At a limit, below all of these: compound 2.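

In this assay, pyridin-2-yl and 2,4-dichlorophenyl on the amide-type nitrogen cannot be told apart, although the entering group has fewer heavy atoms, no chlorine and one hydrogen-bond acceptor: a 1.4-fold higher number from compound 3 to compound 4 (0.15 log units; within the scatter). Pyridin-2-yl in place of phenyl, by contrast, is a step beyond the scatter, a 2.2-fold lower number from compound 1 to compound 4 (0.34 log units; beyond the scatter), so among the three numbers in hand, the plain phenyl amide of compound 1 stands apart from two quite different aryl groups, while the 4-bromo-3-methylphenyl group of compound 2 can be placed only through a limit. For compound 2 the step is therefore open-ended, an at least 29-fold higher number from compound 2 to compound 4 (1.46 log units; beyond the scatter), and its value is a limit of the assay, not a number: the limit of < 1000 nM in this assay, at which 1 of the 4 values shown sits.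

From the compounds shown here alone, what separates compound 1 from compounds 3 and 4 stays open, since three aryl groups cannot show whether the ring nitrogen, either chlorine alone or the two chlorines together set the number at this position. Also open, going by these compounds, is how this assay responds to an amine or a carboxylic acid on the aryl ring, or to a longer chain between the amide-type nitrogen and that ring.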